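This account rests on a few compounds, and the source may have more. Where it says the series, first, only, none or still open, it means among the compounds named here.

Measured compounds:
compound 1, `CC(C)Oc1ccc(C2CN(C)[C@]3(C(=O)Nc4ccccc43)[C@]23NC(=S)N(c2ccc(F)c(Cl)c2)C3=O)cc1`, 13500 nM
compound 2, `CCOc1ccc(N2C(=O)[C@@]3(NC2=S)C(c2ccc(Cl)cc2)CN(C)[C@]32C(=O)Nc3ccc(Br)cc32)cc1`, 28600 nM

Among the compounds with values here, the two compounds measured so far share a core and were both tested in an ADME assay on HEK293 cells (Homo sapiens) for cytotoxicity, read by MTT assay, with a stated time of 48 h; a lower number here means a stronger inhibitor, a higher number a weaker inhibitor. Compound 1 gives 13500 nM in this assay, the lower of the two numbers. Compound 2 gives 28600 nM, a gap from compound 1 that lies beyond the scatter of repeated measurements. The two compounds differ from each other in several places at once, so no single structural change can be tied to that gap; the values simply show compound 1 as the stronger inhibitor of the pair.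

The unmeasured compound 3, `CCc1ccc(C2CN(C)[C@]3(C(=O)Nc4ccccc43)[C@]23NC(=S)N(c2ccc(F)c(Cl)c2)C3=O)cc1`, differs from compound 1 in one place only:

ethyl in place of isopropoxy on an aromatic carbon

Within the data shown here, nothing among the measured compounds tests this change on its own, so the direction of the step is open. Two close analogues of a weakly cytotoxic core are expected to stay near each other, and the step of a 1.1-fold higher number from compound 1 to compound 3 (0.05 log units; within the scatter) is estimated to lie within the scatter. Compound 3 is thus expected to give about 15000 nM in this assay, within a range of 6000 nM to 40000 nM.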

Compound 3, half-maximal inhibitory concentration: 12500 nM
For compound 3 the middle estimate is 1.2-fold (0.08 log units) above the measured one; measured number inside the range.
By their numbers in this assay, from the lowest: compounds 3 and 1 (each within the scatter of the next); then compound 2.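

In this assay, within the data shown here, ethyl in place of isopropoxy on an aromatic carbon, para to a large group, gives a 1.1-fold lower number from compound 1 to compound 3 (0.03 log units; within the scatter), the first step in this set that can be tied to a single structural change. The group that leaves contains oxygen and a hydrogen-bond acceptor, whereas the smaller group that enters contains neither, yet compound 1 and compound 3 remain within the scatter of each other, so this one exchange, 4-isopropoxyphenyl to 4-ethylphenyl, leaves no readable difference in this cytotoxicity measure. No supporting measurement offers an explanation for this result.

The compounds shown leave open whether an amine, a carboxylic acid, a hydroxyl or a longer chain such as butyl at this position would also stay within the scatter of compound 1 and compound 3. Among these compounds, they also leave open whether ethyl in place of isopropoxy would give a similar result if the other groups on the shared core were different, since this single pair provides the only direct comparison.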